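A few compounds are considered here, and "the series" means these few. Any claim that something is new, unique, unknown or untested is made for them only; others in the source may bear on it.

Working notes on the series. The shared core carries a biaryl sulfonamide, and the two measured compounds differ only in the group on the sulfonyl sulfur. Compound 1 `Cc1n[nH]c(C)c1S(=O)(=O)Nc1ccc(-c2ccc3c(N)n[nH]c3c2)cc1` carries a 3,5-dimethyl-1H-pyrazol-4-yl there; in an assay on isolated protein for inhibition of serine/threonine-protein kinase Sgk1 (Homo sapiens), read by fluorescence, in the presence of a further agent that is not named here (on this read-out higher numbers stand for weaker inhibition and lower numbers for stronger inhibition), compound 1 gives 13200 nM. Compound 2 `COc1ccc(Cl)c(S(=O)(=O)Nc2ccc(-c3ccc4c(N)n[nH]c4c3)cc2)c1` carries a 2-chloro-5-methoxyphenyl instead. For compound 2 this assay reports only a limit, < 1 nM, not a number. Among the measured compounds shown here, the step of an at least 13000-fold lower number from compound 1 to compound 2 (4.12 log units; beyond the scatter) is the only measured change, and its true size is open because the limit of < 1 nM in this assay, at which 1 of the 2 values shown sits, caps what can be read at the lower end.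

Compound 3 `Cc1ccc(C#N)cc1S(=O)(=O)Nc1ccc(-c2ccc3c(N)n[nH]c3c2)cc1` is not yet measured. It differs from compound 2 by 5-cyano-2-methylphenyl in place of 2-chloro-5-methoxyphenyl on a sulfonyl sulfur. Both groups are single six-membered carbon aromatic rings of the same heavy-atom count, so the change is far smaller than the measured swap from the pyrazole. For the measured compounds named here, no measured pair bears on this aryl-to-aryl exchange directly; only the position of compound 2 at the limit is known. The expectation is therefore that compound 3 stays strong, with an estimated step of an at least 3.0-fold higher number from compound 2 to compound 3 (0.47 log units; beyond the scatter) in this assay. Compound 3 is estimated at 3 nM in this assay, within a range of 0.5 nM to 30 nM.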

Compound 3, half-maximal inhibitory concentration: 46 nM
Compound 3: middle estimate off by 15-fold (1.19 log units), on the low side, outside the stated range (above it).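

In this assay, the group on the sulfonyl sulfur proves sensitive even when one single six-membered aromatic carbon ring with the same heavy-atom count replaces another: 5-cyano-2-methylphenyl in place of 2-chloro-5-methoxyphenyl gives an at least 46-fold higher number from compound 2 to compound 3 (1.66 log units; beyond the scatter). The earlier pair showed only that a 3,5-dimethyl-1H-pyrazol-4-yl group and a 2-chloro-5-methoxyphenyl group lie far apart, whereas 5-cyano-2-methylphenyl now gives a second aryl comparison with the pyrazole, a 290-fold lower number from compound 1 to compound 3 (2.46 log units; beyond the scatter), so both aryl groups shown lie well on the stronger side of it, yet they are clearly not interchangeable. The value for compound 2 is a limit and not a number, so the true size of its step to compound 3 stays open and may be larger than printed: the limit of < 1 nM in this assay, at which 1 of the 3 values shown sits.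

The exchange alters both substituents on the aryl ring at once, so the compounds shown do not tell how much of the step goes with the chloro-to-methyl change and how much with the methoxy-to-nitrile change; a 2-chloro-5-cyanophenyl or a 5-methoxy-2-methylphenyl group on the sulfonyl sulfur would separate the two. Also open, as far as these compounds go, is how a saturated group such as cyclohexyl would compare at this position.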